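A few compounds are considered here, and "the series" means these few. Any claim that something is new, unique, unknown or untested is made for them only; others in the source may bear on it.

Values so far in an ADME assay on Raji cells (Homo sapiens) for cytotoxicity, read by luminescence, with a stated time of 72 h (on this read-out lower numbers stand for an effect already at smaller amounts and higher numbers for an effect only at larger amounts of compound), are all limits, not numbers:
- Compound 1 (`CCOC(=O)c1c(-c2cccc(OC)c2)[nH]c2cc(OC)ccc2c1=O`) gives > 21500 nM as a limit.
- Compound 2 (`CCCCOc1cccc(-c2[nH]c3cc(OC)ccc3c(=O)c2C(=O)OCC)c1`) gives > 21500 nM as a limit.
- Compound 3 (`CCOC(=O)c1c(-c2cccc(F)c2)[nH]c2cc(OC)ccc2c1=O`) gives > 21500 nM as a limit.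

Compound 3 therefore has no numerical position, and the series rests on the limit of > 21500 nM in this assay, at which 3 of the 3 values shown sit, alone. Compound 4 (`CCOC(=O)c1c(-c2cccc(Br)c2)[nH]c2cc(OC)ccc2c1=O`) carries bromo in place of fluoro on an aromatic carbon, read as 3-fluorophenyl to 3-bromophenyl. The nearest measured steps, a step that the two limits leave unreadable from compound 1 to compound 3 and a step that the two limits leave unreadable from compound 2 to compound 3, also exchange a group on an aromatic carbon, and neither has a readable size. No change beyond the scatter, in either direction, is expected in this assay, so the expected step is a step that the limit leaves unreadable from compound 3 to compound 4 and no more. The estimate for compound 4 is 22000 nM with an expected range from 10000 nM to 40000 nM and a further limit as the likeliest report.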

Compound 4, half-maximal effective concentration: > 21500 nM
Compound 4: no number, only a limit; the forecaster's own chance of this, stated with the estimate: 85%; the middle value lies beyond the limit too.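

No step can be read among compound 1, compound 2, compound 3 and compound 4, as all four rest on one shared limit: the limit of > 21500 nM in this assay, at which 4 of the 4 values shown sit.

The compounds shown leave open how far any of these aromatic substituents shifts the read-out in this assay.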